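A few compounds are considered here, and "the series" means these few. Any claim that something is new, unique, unknown or untested is made for them only; others in the source may bear on it.

Working notes on the series.

Within the data shown here, compound 1 `Cc1cc(-c2cnn3c(NCC4CCOCC4)nc(NC4CCOCC4)nc23)ccc1C(=O)NC1CC1` is the only member with a number in a functional assay on MDA-MB-231 cells (Homo sapiens) for antiproliferative activity; a lower number here means a stronger inhibitor of growth, a higher number a weaker inhibitor of growth: in this assay compound 1 gives 540 nM. Two further members carry no result. Compound 2 `CC(C)C(=O)Nc1ccc(-c2cnn3c(NCC4CCOCC4)nc(OC4CCCC4)nc23)cc1` has in this assay "not determined" (no result reported), and compound 3 `Cc1cc(-c2cnn3c(NCC4CCOCC4)nc(NC4CCCC4)nc23)ccc1NC(=O)C1CC1` likewise has in this assay "not determined" (no result reported). Compound 1 therefore stands alone, with nothing measured to rank it against.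

Compound 4 `CC(=O)Nc1cccc(Oc2nc(NCC3CCOCC3)n3ncc(-c4ccc(C(=O)NC5CC5)c(C)c4)c3n2)c1` differs from compound 1 in one place: 3-acetamidophenoxy in place of (oxan-4-yl)amino on an aromatic carbon. Among the measured compounds shown here, no pair of measured compounds covers a change of this kind, so the size of the step in this assay rests on the single value of compound 1 alone and not on any observed trend. Without a measured step of comparable type, the expectation is a step of modest size, leaning toward somewhat stronger growth inhibition, but with a range wide enough to admit no change beyond the scatter or a slight loss. The expected step from compound 1 to compound 4 is a 1.2-fold lower number from compound 1 to compound 4 (0.08 log units; within the scatter). For compound 4 the estimate in this assay is 450 nM, expected to fall between 130 nM and 1600 nM.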

Compound 4, concentration for 50% growth inhibition: 1600 nM
Compound 4: the middle estimate sits 3.6-fold (0.55 log units) below what was measured; measured number inside the range.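

Swapping (oxan-4-yl)amino for 3-acetamidophenoxy on this aromatic carbon gives the first measured step in the series: in this assay there is a 3.0-fold higher number from compound 1 to compound 4 (0.47 log units; beyond the scatter). This position is therefore not indifferent to the group it carries, although the larger group, with its six-membered aromatic ring, still leaves a measurable growth-inhibition value. The change alters the linking atom and the ring at once, and this single step cannot separate the two. No available evidence bears on the reason for this step.

On these data alone, it remains open whether the linking oxygen, the aromatic ring or the acetamido group accounts for the step. As far as these compounds go, an unsubstituted phenoxy group or a phenylamino group on this carbon would address that, and the effect of either on the number remains unknown.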